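The compounds below may be only part of what the source reports. "The series", "measured", "known", "first", "only" and "open" are said of these compounds alone.

Of the compounds shown here, three sharing one core have been read in an ADME assay on L6 cells (Rattus norvegicus) for cytotoxicity, read by resazurin assay, with a stated time of 72 h; on this read-out higher numbers stand for weaker inhibition and lower numbers for stronger inhibition. Compound 1 `OC(c1ccc(Cl)cc1)(c1ccc(C(F)(F)F)cc1)c1cccnc1` gives 56400 nM. Compound 2 `OC(c1ccc(Br)cc1)(c1ccc(C(F)(F)F)cc1)c1cccnc1` gives 54700 nM. Bromo in place of chloro thus makes a 1.0-fold lower number from compound 1 to compound 2 (0.01 log units; within the scatter). Compound 3 `NC(=O)c1ccc(C(O)(c2ccc(C(F)(F)F)cc2)c2cccnc2)cc1`, with carbamoyl at that place, gives > 100000 nM, which is a limit of the assay and not a number. The measured steps to it are an at least 1.7-fold higher number from compound 1 to compound 3 (0.24 log units; that floor lies within the scatter) and an at least 1.8-fold higher number from compound 2 to compound 3 (0.26 log units; that floor lies within the scatter), so compound 3 is not shown to stand apart from the chloro and bromo compounds.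

Compound 4 `CN(C)c1ccc(C(O)(c2ccc(C(F)(F)F)cc2)c2cccnc2)cc1` changes this same place, with dimethylamino in place of carbamoyl on an aromatic carbon, para to a large group: dimethylamino in place of carbamoyl on an aromatic carbon. No measured compound carries dimethylamino, so the only guides are the three steps at this place, none of which is shown beyond the scatter. With compound 1 at 56400 nM and compound 2 at 54700 nM, compound 4 is expected to fall in the same region, with a modest move to a lower number at most. The estimated step is an at least 1.8-fold lower number from compound 3 to compound 4 (0.25 log units; that floor lies within the scatter). For compound 4 the estimate is 55000 nM, with an expected range from 22000 nM to 100000 nM.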

Compound 4, half-maximal inhibitory concentration: 59100 nM
Compound 4: the middle estimate sits 1.1-fold (0.03 log units) below what was measured; the range from low to high includes it.
By their numbers in this assay, from the lowest: compounds 2, 1 and 4 (each within the scatter of the next). At a limit, above all of these: compound 3.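

In this assay, dimethylamino on an aromatic carbon, para to a large group, gives a reading that cannot be told apart from those of chloro and bromo at this place: a 1.0-fold higher number from compound 1 to compound 4 (0.02 log units; within the scatter) and a 1.1-fold higher number from compound 2 to compound 4 (0.03 log units; within the scatter). Among the compounds shown here, the earlier compounds held only chloro, bromo and carbamoyl here, so this is the first sign that a nitrogen-linked group with no hydrogen-bond donor can take this place and leave the reading within the scatter of the two halogen compounds. The step from carbamoyl is an at least 1.6-fold lower number from compound 3 to compound 4 (0.22 log units; that floor lies within the scatter), and it gives only a floor, so dimethylamino is not shown to stand apart from carbamoyl either, and the true size of this step stays unknown: the limit of > 100000 nM in this assay, at which 1 of the 4 values shown sits.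

Across these four compounds, no group at this place is shown to move the reading beyond the scatter, and it remains open whether a carboxylic acid or a primary amine here would do so. The compounds shown also leave open what happens when the trifluoromethyl group on the shared core gives way to a nitrile or a methoxy group.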